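The source may hold more compounds than are shown below. What is called first, only, known or untested is meant among the compounds shown, and "the series" means these compounds.

In a functional assay on HCC827 cells (Homo sapiens) for cytotoxicity, read by MTT assay, with a stated time of 72 h (on this read-out higher numbers stand for weaker inhibition and lower numbers for stronger inhibition), compound 1 `OCCNc1ccc(Nc2ncc3nc(Nc4ccccc4)n(C4CCCC4)c3n2)cc1` gives 2.8 nM. Compound 2 `CN1CCN(c2ccc(Nc3ncc4nc(Nc5cccc([N+](=O)[O-])c5)n(C5CCCC5)c4n3)cc2)CC1` gives < 0.01 nM, which is a limit and not a number. From the compounds shown here alone, compound 2 therefore stands at the limit of < 0.01 nM in this assay, at which 1 of the 2 values shown sits, so its exact position is unknown. Compound 3 `CN1CCN(c2ccc(Nc3ncc4nc(Nc5ccc(Br)cc5F)n(C5CCCC5)c4n3)cc2)CC1` keeps the rest of compound 2 and carries 4-bromo-2-fluorophenyl in place of 3-nitrophenyl on a nitrogen on an aromatic ring. For the measured compounds named here, no measured pair of compounds shows what a change at this place does in this assay, so any expectation here is tentative. Since compound 2 reads < 0.01 nM, a measurable number for compound 3 would be expected on the side of weaker inhibition. The estimated step of an at least 10-fold higher number from compound 2 to compound 3 (1.00 log units; beyond the scatter) is therefore expected to run toward weaker inhibition and to be moderate in size. Compound 3 is estimated at 0.1 nM, with an expected range from 0.01 nM to 2 nM.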

Compound 3, half-maximal inhibitory concentration: 2.3 nM
Beside the measured number, compound 3's estimate is 23-fold (1.36 log units) below it; the measured number lies above the stated range.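

In this assay, for the compounds shown here, the swap of 3-nitrophenyl for 4-bromo-2-fluorophenyl on a nitrogen on an aromatic ring gives the first measured step at this place: an at least 230-fold higher number from compound 2 to compound 3 (2.36 log units; beyond the scatter). The aryl group on this nitrogen therefore matters in this series, and a change here alone can shift the read-out by a large step toward weaker inhibition. The true size of that step stays unknown, since the value of compound 2 is a limit and not a number: the limit of < 0.01 nM in this assay, at which 1 of the 3 values shown sits.

One swap removes the nitro group and brings in bromine and fluorine together, so the compounds shown do not tell which of these changes accounts for the step. From the compounds shown here alone, how an amine or a methoxy group on this phenyl ring would read in this assay remains open.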